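From Nitro to Methoxy: Estimating Compound 3

The source may report more compounds than this note shows. Statements on the series, on what has been measured and on what is new or still open speak of the compounds shown alone.

Compound 1 `Oc1ccc(O)c(/C=N/c2ccc(OCc3ccccc3)cc2)c1` in a functional assay, with a stated time of 30 min (a lower number here means a stronger inhibitor, a higher number a weaker inhibitor), gives 21300 nM.
Compound 2 `O=[N+]([O-])c1ccc(O)c(/C=N/c2ccc(OCc3ccccc3)cc2)c1` in this assay gives only a limit, > 200000 nM.

Compound 2 thus sits at the limit of this assay rather than at a number (the limit of > 200000 nM in this assay, at which 1 of the 2 values shown sits). For the measured compounds named here, the one measured step leading to it, an at least 9.3-fold higher number from compound 1 to compound 2 (0.97 log units; beyond the scatter), shows that nitro in place of hydroxy weakened inhibition at least modestly. Compound 3 `COc1ccc(O)c(/C=N/c2ccc(OCc3ccccc3)cc2)c1` differs from compound 2 by methoxy in place of nitro on an aromatic carbon. Since that step undoes the nitro, compound 3 is expected to return toward the number of compound 1, a downward step an at least 3.3-fold lower number from compound 2 to compound 3 (0.52 log units; beyond the scatter), though a limit remains possible. Compound 3 is estimated at 60000 nM, within 15000 nM to 200000 nM.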

Compound 3, half-maximal inhibitory concentration: > 200000 nM
Compound 3: only a limit was reported; the forecaster's own chance of this, stated with the estimate: 30%; middle value at least 3.3-fold (0.52 log units) from the limit.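

Methyl in place of hydrogen on the oxygen at this position weakens inhibition, with an at least 9.3-fold higher number from compound 1 to compound 3 (0.97 log units; beyond the scatter) in this assay. So the loss seen with nitro is not confined to that group: methoxy, which keeps the oxygen, also falls beyond the scatter from the hydroxy group of compound 1. Methoxy and nitro cannot be ranked against each other, because compound 2 and compound 3 both stand at a limit rather than a number: the limit of > 200000 nM in this assay, at which 2 of the 3 values shown sit.

Still open, on these data alone, is whether any other group at this position can match the hydroxy group. An amine or a fluorine there would test this.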